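The compounds below may be only part of what the source reports. "The series", "measured", "known", "first", "only" and "open" are said of these compounds alone.

Measured in a functional assay on the whole organism for antagonist activity, with Mus musculus as the target; on this read-out lower numbers stand for an effect already at smaller amounts and higher numbers for an effect only at larger amounts of compound:
Compound 1 `Cn1c(-c2ccccc2)nnc1S(C)(=O)=O`: 55 mg/kg
Compound 2 `Cc1ccc(-c2nnc([S+](C)[O-])n2C)cc1`: > 200 mg/kg

Compound 2 has no exact number on this read-out, since its > 200 mg/kg is only a limit of this assay. Compound 3 `Cc1ccc(-c2nnc(S(C)(=O)=O)n2C)cc1` differs from compound 2 in one place, an aromatic carbon of a five-membered aromatic ring with 3 nitrogen, where a methylsulfonyl group replaces a group of 3 heavy atoms (a group of 4 heavy atoms (1 carbon, 2 oxygen, 1 sulfur; no ring) in place of a group of 3 heavy atoms (1 carbon, 1 oxygen, 1 sulfur; no ring), on an aromatic carbon). Among the compounds with values here, no measured pair isolates this change, so the only guide is compound 1, which also carries methylsulfonyl and gives 55 mg/kg. Compound 3 is therefore expected to read near that value, a step beyond the scatter towards smaller amounts. The expected size of this change is an at least 3.3-fold lower number from compound 2 to compound 3 (0.52 log units; beyond the scatter). For compound 3 the estimated value is 60 mg/kg, with an expected range from 22 mg/kg to 170 mg/kg.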

Compound 3, dose for half-maximal effect: > 200 mg/kg
Compound 3: only a limit was reported; the forecaster's own chance of this, stated with the estimate: 20%; middle value at least 3.3-fold (0.52 log units) away from the limit.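

In this assay compound 3 gives > 200 mg/kg, which is a limit of the assay and not a number. With methylsulfonyl on this aromatic carbon in both compounds, methyl in place of hydrogen on an aromatic carbon at the other end of the molecule gives an at least 3.6-fold higher number from compound 1 to compound 3 (0.56 log units; beyond the scatter), so methylsulfonyl at this position does not by itself secure the reading of compound 1. The change from the group of 3 heavy atoms to methylsulfonyl cannot be read, since compound 2 and compound 3 stand at the same limit: the limit of > 200 mg/kg in this assay, at which 2 of the 3 values shown sit.

Going by these compounds, how far compound 2 and compound 3 lie beyond that limit stays open. Also open, on these data alone, is whether an amine or a longer chain on this aromatic carbon would give a measurable reading alongside the added methyl.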